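A few compounds are considered here, and "the series" means these few. Any claim that something is new, unique, unknown or untested is made for them only; others in the source may bear on it.

Of the compounds shown here, two on the shared core have been read so far in a functional assay on CEM13 cells (Homo sapiens) for cytotoxicity, read by MTT assay, with a stated time of 72 h; on this read-out higher numbers stand for weaker inhibition and lower numbers for stronger inhibition. Compound 1 (`Cc1c(C)c2c(c(C)c1O)CCC(C)(C(=O)NC1CC(C)(C)N([O])C(C)(C)C1)O2`) gives > 300000 nM, which is a limit of the assay and not a number. Among the measured compounds shown here, compound 2 (`Cc1c(C)c2c(c(C)c1OC(=O)CCC(=O)O)CCC(C)(C(=O)O)O2`) gives 191000 nM, the only true number in hand, so it is the single anchor for the series.

Compound 3 (`Cc1c(C)c2c(c(C)c1OC(=O)CCC(=O)O)CCC(C)(C(=O)NC1CC(C)(C)N([O])C1(C)C)O2`) keeps the core of compound 2 and changes one place, on a carbonyl carbon whose other neighbour is a saturated ring carbon: a group of 11 heavy atoms (8 carbon, 2 nitrogen, 1 oxygen; one five-membered non-aromatic ring with 1 hetero atom) in place of one oxygen atom, on a carbonyl carbon. For the measured compounds named here, no measured pair isolates this change, so the expectation starts from compound 2 at 191000 nM and carries wide uncertainty. The expected step is a 2.4-fold lower number from compound 2 to compound 3 (0.38 log units; beyond the scatter), a modest move towards stronger inhibition in this assay, and a result within the usual scatter would not be surprising. For compound 3 the estimated value is 80000 nM, with an expected range of 25000 nM to 250000 nM.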

Compound 3, half-maximal inhibitory concentration: 205000 nM
Compound 3: the middle estimate sits 2.6-fold (0.41 log units) below what was measured, and the stated range covers the measured number.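

In this assay, putting the group of 11 heavy atoms with its five-membered non-aromatic ring in place of the hydroxy, on a carbonyl carbon whose other neighbour is a saturated ring carbon, gives no readable shift: a 1.1-fold higher number from compound 2 to compound 3 (0.03 log units; within the scatter). Among the compounds shown here, this is the only step that can be read so far, and it shows that this position accepts a much larger group with no change in the number beyond the scatter. Compound 1 stands at a limit of the assay and not a number, so the read-out has a bound at the weak end of the series: the limit of > 300000 nM in this assay, at which 1 of the 3 values shown sits.

Going by these compounds, whether a simple amine or a longer alkyl chain on this carbonyl carbon would give a number apart from that of compound 2 stays open. With one step in hand, no trend at this position can be stated.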